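A few compounds are considered here, and "the series" means these few. Any claim that something is new, unique, unknown or untested is made for them only; others in the source may bear on it.

Measured so far in a functional assay on thoracic aorta for antagonist activity at Alpha-1D adrenergic receptor (Rattus norvegicus); a higher number here means a more potent compound, by a factor of ten per unit of this negative logarithm, a lower number a less potent compound:
- compound 1 `COc1cccc(OC)c1OCCNCCOc1ccccc1OCc1ccc(Cl)cc1` gives 9.11
- compound 2 `COc1cccc(OC)c1OCCNCCOc1ccccc1OCc1ccccc1[N+](=O)[O-]` gives 8.95
- compound 3 `COc1cccc(OC)c1OCCNCCOc1ccccc1OCc1ccc([N+](=O)[O-])cc1` gives 9.41

Compound 3 holds the highest of the three numbers, but compound 1 lies within the scatter of it, so the two cannot be ranked; only compound 2 stands clearly apart, the step of a number 0.46 log units higher from compound 2 to compound 3 (beyond the scatter) being beyond the scatter. Compound 4 `COc1cccc(COc2ccccc2OCCNCCOc2c(OC)cccc2OC)c1` has not yet been measured. Against compound 3 the change is 3-methoxyphenyl in place of 4-nitrophenyl on a saturated chain carbon bound to an oxygen on an aromatic ring.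

All three measured steps concern the same benzyl ring and bear on this change, though none of them puts a methoxy group there. The step of a number 0.30 log units higher from compound 1 to compound 3 (within the scatter) and the step of a number 0.16 log units lower from compound 1 to compound 2 (within the scatter) are both within the scatter; the step of a number 0.46 log units higher from compound 2 to compound 3 (beyond the scatter) is modest. Changes at this ring have thus moved this assay only a little, with the number staying high throughout. A small downward step is therefore expected in this assay for compound 4, most likely within the scatter, as a number 0.46 log units lower from compound 3 to compound 4 (beyond the scatter). Compound 4 is estimated at 8.95, within a range from 8.45 to 9.45.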

Compound 4, negative logarithm of the antagonist equilibrium constant: 9.12
Estimate against measurement, compound 4: 0.17 log units below; the measured number falls inside the stated range.
By their numbers in this assay, from the lowest: compounds 2, 1, 4 and 3 (each within the scatter of the next, the first and the last beyond it).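

In this assay, going by these compounds alone, compound 4 is the first to carry neither nitro nor chloro on this benzyl ring, and its 3-methoxyphenyl sits within the scatter of all three earlier groups (a number 0.29 log units lower from compound 3 to compound 4 (within the scatter); a number 0.17 log units higher from compound 2 to compound 4 (within the scatter); a number 0.01 log units higher from compound 1 to compound 4 (within the scatter)). The tolerance seen among the chloro and nitro compounds at this place, on a saturated chain carbon bound to an oxygen on an aromatic ring, therefore extends to a methoxy-bearing ring, and the number stays high. Within the data shown here, the only pair still separated beyond the scatter is compound 2 and compound 3 (a number 0.46 log units higher from compound 2 to compound 3 (beyond the scatter)), so compound 4 adds no second clear difference, and nothing available here accounts for this flat picture.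

Going by these compounds, whether the number would hold with a more different group on this ring, such as an amine or a carboxylic acid, stays open, as does the effect of a longer chain in place of the single saturated chain carbon. The compounds shown also leave open how these benzyl changes read at any other receptor, since all four values come from this assay.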